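The compounds below may be only part of what the source reports. "The series", "measured", "known", "first", "only" and "open" are said of these compounds alone.

Working notes on the series. For the measured compounds named here, in an ADME assay on HEK-293T cells (Homo sapiens) for cytotoxicity, read by resazurin assay, with a stated time of 16 h (on this read-out higher numbers stand for weaker inhibition and lower numbers for stronger inhibition), compound 1 (`OC[C@H]1O[C@@H](n2cnc3c(NC4CCCC4)nc(NC4CCCCCC4)nc32)[C@H](O)[C@@H]1O`) gives 167000 nM, the only number so far. Compound 2 (`OC[C@H]1O[C@@H](n2cnc3c(N4CCCCC4)nc(NC4CCCC4)nc32)[C@H](O)[C@@H]1O`) has no place on this scale, its entry reading "not determined" (no result reported). Compound 3 (`OC[C@H]1O[C@@H](n2cnc3c(N4CCCCC4)nc(N4CCCCC4)nc32)[C@H](O)[C@@H]1O`) is likewise without a number, at "not determined" (no result reported). Compound 4 (`OC[C@H]1O[C@@H](n2cnc3c(NC4CCCCCC4)nc(NC4CCCC4)nc32)[C@H](O)[C@@H]1O`) carries cycloheptylamino in place of the piperidin-1-yl of compound 2 on an aromatic carbon. Counted difference: cycloheptylamino in place of piperidin-1-yl on an aromatic carbon. Going by the values given here, no measured step exists to size this change, so the expectation in this assay rests only on compound 1 at 167000 nM, and no direction is assigned. Compound 4 is estimated at 150000 nM, with an expected range of 60000 nM to 350000 nM.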

Compound 4, half-maximal inhibitory concentration: > 500000 nM
Compound 4 was reported as a limit; the forecaster's own chance of this, stated with the estimate: 30%; middle value at least 3.3-fold (0.52 log units) away from the limit.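

In this assay, for the compounds shown here, compound 4 gives > 500000 nM, a limit and not a number, and no step between compound 2 and compound 4 can be read. Going by these compounds, how cycloheptylamino in place of piperidin-1-yl moves this read-out stays open.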